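Anilide series: switching the distal aryl group

The compounds below may be only part of what the source reports. "The series", "measured", "known", "first", "only" and "open" are said of these compounds alone.

Measured compounds:
- compound 1 `COC(=O)/C=C/c1cccc(N(Cc2ccc(/C=C/c3cccc(C(F)(F)F)c3)cc2)C(=O)NC(C)C)c1` gives 932 nM in an assay on isolated protein with Bile acid receptor (Homo sapiens) as the target; on this read-out higher numbers stand for an effect only at larger amounts of compound and lower numbers for an effect already at smaller amounts
- compound 2 `COC(=O)/C=C/c1cccc(N(Cc2ccc(/C=C/c3scnc3C)cc2)C(=O)C(C)C)c1` gives 228 nM in this assay
- compound 3 `COC(=O)/C=C/c1cccc(N(Cc2ccc(-c3ccc(C(C)(C)C)cc3)cc2)C(=O)C2CCCCC2)c1` gives 132 nM in this assay

Compound 3 carries the lowest number of the three shown. Compound 2 lies within the usual scatter of compound 3, so the two cannot be separated on these data; compound 1 lies beyond the scatter of compound 3 and shows the weaker effect. For the measured compounds named here, no pair among the three differs in one place only, so no single step can be read from them.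

Compound 4 `COC(=O)/C=C/c1cccc(N(Cc2ccc(-c3cccc(OC(F)(F)F)c3)cc2)C(=O)C2CCCCC2)c1` is yet to be measured. Relative to compound 3 it differs as follows: 3-(trifluoromethoxy)phenyl in place of 4-(tert-butyl)phenyl on an aromatic carbon

The other parts of compound 3, with the cyclohexanecarbonyl group on the anilide, are kept. Going by the values given here, with no direct step available for this kind of change, the step of a 2.0-fold higher number from compound 3 to compound 4 (0.29 log units; within the scatter) is expected to be small, toward a somewhat higher number, and may well fall within the scatter. Compound 4 is therefore estimated at 260 nM, in a range from 80 nM to 850 nM.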

Compound 4, half-maximal effective concentration: 420 nM
Compound 4: middle estimate off by 1.6-fold (0.21 log units), on the low side; measured number inside the range.
By their numbers in this assay, from the lowest: compounds 3, 2 and 4 (each within the scatter of the next, the first and the last beyond it); then compound 1.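

With the cyclohexanecarbonyl group on the anilide held fixed, the series gains its first step that differs in one place: in this assay, 3-(trifluoromethoxy)phenyl in place of 4-(tert-butyl)phenyl gives a 3.2-fold higher number from compound 3 to compound 4 (0.50 log units; beyond the scatter). The distal aryl group therefore affects the read-out in this assay, with a modest step that lies beyond the usual scatter. Nothing at hand bears on what lies behind this step.

The two groups differ both in the substituent and in where it sits on the ring, so these two contributions cannot be separated from this single step. Also open, from the compounds shown here alone, is how the distal aryl position would respond to an amine or a nitrile, and whether a carboxylic acid in place of the methyl ester would shift the number with this anilide.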